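A few compounds are considered here, and "the series" means these few. Any claim that something is new, unique, unknown or untested is made for them only; others in the source may bear on it.

Measured so far in a functional assay on HT-29 cells (Homo sapiens) for inhibition, read by MTT assay, with a stated time of 48 h; a higher number here means a weaker inhibitor, a lower number a stronger inhibitor:
- compound 1 `COc1cc(/C=C/c2ccc(NC(=O)/C=C/c3cc(OC)c(O)c(OC)c3)cc2)cc(OC)c1`: 3080 nM
- compound 2 `COc1cc(/C=C/c2ccc(NC(=O)/C=C/c3ccc(F)cc3)cc2)cc(OC)c1`: 11600 nM
- compound 3 `COc1cc(/C=C/c2ccc(NC(=O)/C=C/c3ccc(Cl)cc3)cc2)cc(OC)c1`: 10300 nM

Compound 3 sits second highest of the three numbers. Its nearest neighbour is compound 2, and the gap between them, a 1.1-fold lower number from compound 2 to compound 3 (0.05 log units; within the scatter), lies within the scatter, so the two cannot be ordered. The furthest is compound 1, from which compound 3 is set apart by a 3.3-fold higher number from compound 1 to compound 3 (0.52 log units; beyond the scatter), a modest step beyond the scatter; the parallel step a 3.8-fold higher number from compound 1 to compound 2 (0.58 log units; beyond the scatter) is of the same kind.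

Compound 4 `COc1cc(/C=C/c2ccc(NC(=O)/C=C/c3ccc(Br)cc3)cc2)cc(OC)c1` differs from compound 3 by bromo in place of chloro on an aromatic carbon, on an aromatic carbon of a six-membered aromatic ring of carbon only, para to a large group. The step that bears directly on it is the halogen exchange at the same place, a 1.1-fold lower number from compound 2 to compound 3 (0.05 log units; within the scatter), which stayed within the scatter. The two steps from compound 1 replace the whole substituted phenyl group and therefore say little about a one-atom halogen swap. A step within the scatter is expected, with no preferred direction, so compound 4 is expected to change by a 1.1-fold lower number from compound 3 to compound 4 (0.04 log units; within the scatter).

Compound 4 is therefore estimated at 9500 nM in this assay, with a range from 4000 nM to 23000 nM.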

Compound 4, half-maximal inhibitory concentration: 5260 nM
Beside the measured number, compound 4's estimate is 1.8-fold (0.26 log units) above it, within the range that was stated.
By their numbers in this assay, from the lowest: compounds 1, 4, 3 and 2 (each within the scatter of the next, the first and the last beyond it).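

In this assay, within the data shown here, the halogen at this aromatic carbon now makes a readable difference: bromo in place of fluoro gives a 2.2-fold lower number from compound 2 to compound 4 (0.34 log units; beyond the scatter), the first halogen exchange here to pass beyond the scatter, though only as a modest step. The neighbouring exchange, a 2.0-fold lower number from compound 3 to compound 4 (0.29 log units; within the scatter), stays within the scatter, so chloro and bromo cannot be ordered, and neither can the chloro and fluoro compounds, which leaves no clean ranking across the three halogens. Among these compounds, the comparison with the larger group is also new: a 1.7-fold higher number from compound 1 to compound 4 (0.23 log units; within the scatter) lies within the scatter, so compound 4 cannot be separated from compound 1, whereas the 4-fluorophenyl and 4-chlorophenyl compounds both stood apart from it, and the 4-hydroxy-3,5-dimethoxyphenyl group is therefore not the only group at this place that reaches this level. Nothing available gives a cause for any of these steps.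

On these data alone, whether a group other than a halogen on this same aromatic carbon, such as an amine, a nitrile or a carboxylic acid, would go beyond the level of compound 4 remains open. Also open, as far as these compounds go, is whether the modest fluoro to bromo step would hold on other cell lines.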